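The source may hold more compounds than are shown below. What is called first, only, known or untested is meant among the compounds shown, and "the series" means these compounds.

Of the compounds shown here, three sharing one core have been measured in a functional assay on CHO-K1 cells for antagonist activity at transient receptor potential cation channel subfamily V member 1 (Homo sapiens), read by FLIPR; a lower number here means a stronger inhibitor, a higher number a weaker inhibitor. Compound 1 `CCCN(CCC)c1nc(C(F)(F)F)ccc1CNC(=O)C(C)c1ccc(NS(C)(=O)=O)c(F)c1` gives 0.2 nM. Compound 2 `CC(C(=O)NCc1ccc(C(F)(F)F)nc1N1CCCC1)c1ccc(NS(C)(=O)=O)c(F)c1` gives 0.6 nM, and compound 3 `CC(C)OC1CCN(c2nc(C(F)(F)F)ccc2CNC(=O)C(C)c2ccc(NS(C)(=O)=O)c(F)c2)CC1` gives 3 nM. Compound 3 therefore stands highest of the three numbers: the step of a 15-fold higher number from compound 1 to compound 3 (1.18 log units; beyond the scatter) and the step of a 5.0-fold higher number from compound 2 to compound 3 (0.70 log units; beyond the scatter) both run upward, as does the step of a 3.0-fold higher number from compound 1 to compound 2 (0.48 log units; beyond the scatter). Going by the values given here, every exchange so far at that aromatic carbon has thus gone with a higher number in this assay, with no compound among the three going against it.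

Compound 4 `CC(C(=O)NCc1ccc(C(F)(F)F)nc1N1CCN(C2CCCCC2)CC1)c1ccc(NS(C)(=O)=O)c(F)c1` has not yet been measured. It differs from compound 3 in one place: 4-cyclohexylpiperazin-1-yl in place of 4-isopropoxypiperidin-1-yl on an aromatic carbon. The group that enters carries more heavy atoms than the one that leaves, while the count of hydrogen-bond acceptors stays the same. The measured steps that bear on this exchange are a 5.0-fold higher number from compound 2 to compound 3 (0.70 log units; beyond the scatter) and a 15-fold higher number from compound 1 to compound 3 (1.18 log units; beyond the scatter), one modest and one large, both upward. Among the compounds with values here, a further upward step beyond the scatter is therefore expected in this assay for compound 4, though its size is uncertain since no measured pair tests this particular group. Compound 4 is expected to give 8 nM, within a range from 2 nM to 40 nM. This estimate corresponds to an expected step of a 2.7-fold higher number from compound 3 to compound 4 (0.43 log units; beyond the scatter).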

Compound 4, inhibition constant: 21.6 nM
For compound 4 the middle estimate is 2.7-fold (0.43 log units) below the measured one; the range from low to high includes it.
By their numbers in this assay, from the lowest: compound 1; then compound 2; then compound 3; then compound 4.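

In this assay the exchange of 4-isopropoxypiperidin-1-yl for 4-cyclohexylpiperazin-1-yl at the aromatic carbon next to the ring nitrogen gave a 7.2-fold higher number from compound 3 to compound 4 (0.86 log units; beyond the scatter), so the number rose further even though the count of hydrogen-bond acceptors stayed the same. Going by these compounds alone, measured against the two groups without a six-membered ring, the change is much larger, with a 36-fold higher number from compound 2 to compound 4 (1.56 log units; beyond the scatter) from the pyrrolidin-1-yl group and a 110-fold higher number from compound 1 to compound 4 (2.03 log units; beyond the scatter) from the dipropylamino group, so this one position now spans a wide range, and the two groups carrying a six-membered non-aromatic ring give the two highest numbers, with no compound among the four going against that. Nothing available explains why these steps run upward or why they are this large.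

The compounds shown leave open whether the higher number of compound 4 goes with the piperazine ring or with the cyclohexyl group on it, a question that a 4-methylpiperazin-1-yl group or a plain piperidin-1-yl group at this carbon could separate. They also leave open whether a shorter open chain, such as diethylamino, would stay as low as dipropylamino.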